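The compounds below may be only part of what the source reports. "The series", "measured", "known", "first", "only" and "open" are said of these compounds alone.

In a functional assay on CHO cells for antagonist activity at prostaglandin E2 receptor EP1 subtype (Homo sapiens), read by FLIPR and calcium flux (a higher number here means a weaker inhibitor, a lower number a stronger inhibitor), compound 1 `CCOc1ccc(Cc2nnc(CN(c3ccccc3CC)S(=O)(=O)c3ccc(C)cc3)o2)cc1` gives 39.8 nM, compound 2 `COc1ccc(Cc2nnc(CN(c3cccc(C(F)(F)F)c3C)S(=O)(=O)c3ccc(C)cc3)o2)cc1` gives 398 nM, and compound 3 `CCOc1ccc(Cc2nnc(CN(c3cccc(Cl)c3C)S(=O)(=O)c3ccc(C)cc3)o2)cc1` gives 50.1 nM. Compound 3 therefore sits second highest of the three numbers. Its nearest neighbour on the numbers is reached by a 1.3-fold higher number from compound 1 to compound 3 (0.10 log units; within the scatter), a step that exchanges the group on the sulfonamide nitrogen and stays within the scatter, while the gap to compound 2 is the largest here and lies beyond the scatter; compounds 2 and 3 differ in more than one place, so their two values alone are all that can be read from them.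

Compound 4 `Cc1ccc(S(=O)(=O)N(Cc2nnc(Cc3c(Cl)cccc3Cl)o2)c2cccc(Cl)c2C)cc1` keeps the whole of compound 3 apart from one change: 2,6-dichlorophenyl in place of 4-ethoxyphenyl on a saturated chain carbon bound to an aromatic carbon. Among the measured compounds shown here, no measured step touches this part of the molecule: the single step in hand alters the other aryl group and was small, so it gives no guide to trading 4-ethoxyphenyl for 2,6-dichlorophenyl. The estimate is accordingly cautious and wide: compound 4 is expected to land at 100 nM, between 25 nM and 400 nM. That expectation amounts to a 2.0-fold higher number from compound 3 to compound 4 (0.30 log units; within the scatter), a step expected to be modest and of uncertain direction.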

Compound 4, inhibition constant: 501 nM
Compound 4: middle estimate off by 5.0-fold (0.70 log units), on the low side, outside the stated range (above it).
By their numbers in this assay, from the lowest: compounds 1 and 3 (each within the scatter of the next); then compounds 2 and 4 (each within the scatter of the next).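

Among the compounds shown here, the group on the saturated chain carbon matters in this assay: exchanging 4-ethoxyphenyl for 2,6-dichlorophenyl gives a 10-fold higher number from compound 3 to compound 4 (1.00 log units; beyond the scatter), a step beyond the scatter, whereas the only earlier step, which changed the group on the sulfonamide nitrogen, stayed within it. With the rest of compound 3 held fixed, 4-ethoxybenzyl therefore gives a stronger inhibitor than 2,6-dichlorobenzyl, so this end of the molecule is sensitive to change. Nothing measured here says why the step is so large.

This single exchange removes the ethoxy group and brings in two chlorines at once, so the compounds shown leave open which of these changes accounts for the step. As far as these compounds go, an unsubstituted benzyl group at this place would help to separate the two, and how a carboxylic acid or an amine on the ring would fare remains unknown.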